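Replacing a Urea by an Alkyl Chain on the Pyrrolidine

A few compounds are considered here, and "the series" means these few. Any claim that something is new, unique, unknown or untested is made for them only; others in the source may bear on it.

The series is built on a shared core, shown in compound 1 `O=C(CN1CCNCC1)N1CCC(NS(=O)(=O)c2cc(S(=O)(=O)c3ccccc3)ccc2C(F)(F)F)CC1`, whose amide carbon carries varied groups. In a functional assay on U2OS cells for antagonist activity at proto-oncogene Wnt-3 (Homo sapiens), read by a luciferase reporter, with a stated time of 18 h (on this read-out lower numbers stand for an effect already at smaller amounts and higher numbers for an effect only at larger amounts of compound), compound 1 gives 250 nM. Compound 2 `CCNC(=O)N1CCC[C@H]1C(=O)N1CCC(NS(=O)(=O)c2cc(S(=O)(=O)c3ccccc3)ccc2C(F)(F)F)CC1` carries a 1-(ethylcarbamoyl)pyrrolidin-2-yl group in place of (piperazin-1-yl)methyl, and in this assay compound 2 gives 90 nM. Compound 2 thus has the lowest of the two numbers seen; its nearest neighbour is compound 1, the gap being a 2.8-fold lower number from compound 1 to compound 2 (0.44 log units; beyond the scatter).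

Compound 3 `CC(C)(C)CCN1CCC[C@H]1C(=O)N1CCC(NS(=O)(=O)c2cc(S(=O)(=O)c3ccccc3)ccc2C(F)(F)F)CC1` differs from compound 2 only as follows: 3,3-dimethylbutyl in place of ethylcarbamoyl on an amine nitrogen in a ring. For the measured compounds named here, only one measured step bears on this region, and it is modest: a 2.8-fold lower number from compound 1 to compound 2 (0.44 log units; beyond the scatter). That step shows that changes at this position shift the number only moderately, so compound 3 is expected to stay near compound 2, with a slight lean toward a higher number because compound 1, whose group also lacks the urea, gives 250 nM. The expected step is a 2.0-fold higher number from compound 2 to compound 3 (0.30 log units; within the scatter). Compound 3 is therefore estimated at 180 nM, within a range from 45 nM to 700 nM.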

Compound 3, half-maximal effective concentration: 450 nM
For compound 3 the middle estimate is 2.5-fold (0.40 log units) below the measured one, within the range that was stated.
By their numbers in this assay, from the lowest: compound 2; then compounds 1 and 3 (each within the scatter of the next).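

In this assay, the change on the amine nitrogen in the ring, 3,3-dimethylbutyl in place of ethylcarbamoyl, gives a 5.0-fold higher number from compound 2 to compound 3 (0.70 log units; beyond the scatter) and lies beyond the scatter, so the lower number of compound 2 does not come with the pyrrolidine carbonyl frame alone but holds only with ethylcarbamoyl among the two groups shown on that nitrogen. The exchange of (piperazin-1-yl)methyl for 1-(3,3-dimethylbutyl)pyrrolidin-2-yl gives a 1.8-fold higher number from compound 1 to compound 3 (0.26 log units; within the scatter) and stays within the scatter, so in this read-out the pyrrolidine frame carrying this alkyl chain cannot be told apart from the group of compound 1. No measurement on hand gives a reason for the shift seen at this nitrogen.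

The compounds shown leave open whether the number follows the carbonyl of the urea, its amide hydrogen, or the length of the chain on the nitrogen. A plain ethyl group, an acetyl group or a urea with a longer chain on this nitrogen would separate these readings, and a free amine on the same nitrogen would show what the bare pyrrolidine gives.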